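The source may report more compounds than this note shows. Statements on the series, on what has been measured and on what is new or still open speak of the compounds shown alone.

Compound 1 `COc1cc(OC)c2c(=O)cc(C3(O)C=CC(=O)C=C3)oc2c1` and compound 2 `COc1cc(OC)c2c(=O)cc(C3(OC)C=CC(=O)C=C3)oc2c1` share one core and differ in a single spot, (methyl in place of hydrogen on an oxygen on a saturated carbon). In a functional assay on MDA-MB-231 cells (Homo sapiens) for cytotoxicity, read by colorimetric assay and MTT assay, with a stated time of 72 h (on this read-out higher numbers stand for weaker inhibition and lower numbers for stronger inhibition), compound 1 gives 540 nM, while compound 2 gives 4700 nM, so this change produced an 8.7-fold higher number from compound 1 to compound 2 (0.94 log units; beyond the scatter). Compound 3 `O=C1C=CC(O)(c2cc(=O)c3ccccc3o2)C=C1` has a different core; the difference between the two cores is not broken down here. In this assay compound 3 gives 710 nM, a number that lies within the usual scatter of the value for compound 1. Compound 4 `COC1(c2cc(=O)c3ccccc3o2)C=CC(=O)C=C1` has not yet been measured. It differs from compound 3 by methyl in place of hydrogen on an oxygen on a saturated carbon, the same change that separates compound 1 from compound 2, at the same kind of place. Because the earlier step was an 8.7-fold higher number from compound 1 to compound 2 (0.94 log units; beyond the scatter), a step of similar size is expected here: an 8.5-fold higher number from compound 3 to compound 4 (0.93 log units; beyond the scatter). Compound 4 is therefore estimated at 6000 nM.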

Compound 4, half-maximal inhibitory concentration: 5490 nM
Compound 4: middle estimate off by 1.1-fold (0.04 log units), on the high side; low and high end bracket the measured number.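

In this assay the change from hydroxy to methoxy gives a 7.7-fold higher number from compound 3 to compound 4 (0.89 log units; beyond the scatter) on the core of compound 3 as well. On these two cores, the step carries over in both direction and size: the same change on two cores in this assay, an 8.7-fold higher number (0.94 log units; beyond the scatter) from compound 1 to compound 2 and a 7.7-fold higher number (0.89 log units; beyond the scatter) from compound 3 to compound 4, 1.1-fold (0.05 log units) apart, within the scatter of two such steps. Among these compounds, this rests on only two cores, however, so it does not show that the step would hold on other cores, nor does it explain why the number rises.

The compounds shown leave open what other groups would do at this place on the saturated carbon, such as a longer chain on the oxygen or an amine in place of the hydroxy. On these data alone, whether the step would keep its size with those groups also remains unknown.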